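Swapping a Nitrile for a Fluorine at the Chain End

This account rests on a few compounds, and the source may have more. Where it says the series, first, only, none or still open, it means among the compounds named here.

Compound 2 `Cc1nc(C)c([C@H](OC(C)(C)C)C(=O)O)c(N2CCC(C)(C)CC2)c1-c1ccc(OCCc2ccc(C#N)cc2)cc1` was tested in a toxicity assay on MT2 cells (Homo sapiens) for cytotoxicity, read by XTT assay, with a stated time of 4 days; on this read-out lower numbers stand for higher toxicity in this test and higher numbers for lower toxicity in this test. In this assay compound 2 gives >= 33500 nM, which is a limit of the assay rather than a number. Compound 1 `Cc1ccc(CCOc2ccc(-c3c(C)nc(C)c([C@H](OC(C)(C)C)C(=O)O)c3N3CCC(C)(C)CC3)cc2)cc1` differs from compound 2 in one place. In this assay compound 1 gives >= 33500 nM, again a limit. The step that the two limits leave unreadable from compound 1 to compound 2 therefore cannot be read, as both results sit at the limit of >= 33500 nM in this assay, at which 2 of the 2 values shown sit. Compound 3 `Cc1nc(C)c([C@H](OC(C)(C)C)C(=O)O)c(N2CCC(C)(C)CC2)c1-c1ccc(OCCCc2ccc(F)cc2)cc1` carries the change (4-fluorobenzyl in place of 4-cyanophenyl on a saturated chain carbon, two bonds along the chain from an oxygen on an aromatic ring). Going by the values given here, no measured step offers a readable size, so the expected step that the limit leaves unreadable from compound 2 to compound 3 is none beyond the scatter. Compound 3 is thus expected at 40000 nM, within 15000 nM to 100000 nM.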

Compound 3, half-maximal cytotoxic concentration: >= 32000 nM
Compound 3: no number, only a limit; the forecaster's own chance of this, stated with the estimate: 80%; the middle value does not contradict the limit.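

Going by these compounds alone, compound 1, compound 2 and compound 3 each give only a limit in this assay, so no step between them can be read. The compounds shown leave open whether changing the chain end alters toxicity at all.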